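From 2-Chlorophenyl to 4-Cyanophenyl on a Shared Core

A few compounds are considered here, and "the series" means these few. Any claim that something is new, unique, unknown or untested is made for them only; others in the source may bear on it.

Compound 1, `C=CC(=O)N1C(=O)CC(c2ccc(C(F)(F)F)cc2)Sc2ccccc21`: 76300 nM
Compound 2, `C=CC(=O)N1C(=O)CC(c2ccccc2Cl)Sc2ccccc21`: 80300 nM

Of the compounds shown here, two have been tested in a functional assay on MOLT-4 cells (Homo sapiens) for cytotoxicity, read by CCK-8 assay, with a stated time of 24 h; a lower number here means a stronger inhibitor, a higher number a weaker inhibitor. Compound 1 gives 76300 nM and compound 2 gives 80300 nM. Compound 2 stands next to compound 1, with the gap between them inside the usual scatter, so neither can be called the stronger. Compound 3, `C=CC(=O)N1C(=O)CC(c2ccc(C#N)cc2)Sc2ccccc21`, is not yet measured. It differs from compound 2 in one place: 4-cyanophenyl in place of 2-chlorophenyl on a saturated ring carbon. For the measured compounds named here, no measured pair shows a change of this kind, so no shift beyond the scatter in this assay is expected in either direction. Compound 3 is estimated at 80000 nM, within 30000 nM to 200000 nM, an expected step of a 1.0-fold lower number from compound 2 to compound 3 (0.00 log units; within the scatter).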

Compound 3, half-maximal inhibitory concentration: 88700 nM
Compound 3: the middle estimate sits 1.1-fold (0.04 log units) below what was measured, and the stated range covers the measured number.
By their numbers in this assay, from the lowest: compounds 1, 2 and 3 (each within the scatter of the next).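

Putting 4-cyanophenyl in place of 2-chlorophenyl on this saturated ring carbon, next to the ring sulfur, gives a 1.1-fold higher number from compound 2 to compound 3 (0.04 log units; within the scatter) in this assay. Cyano in place of trifluoromethyl on the aromatic carbon gives a 1.2-fold higher number from compound 1 to compound 3 (0.07 log units; within the scatter), so neither change separates these compounds in this read-out. No measured information offers an explanation for this.

Still open, going by these compounds, is whether a different group on this phenyl ring, such as an amine or a carboxylic acid, would shift the number beyond the scatter.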